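Replacing the ethynylphenyl arm: notes toward compound 4

The source may hold more compounds than are shown below. What is called first, only, known or untested is meant among the compounds shown, and "the series" means these compounds.

Compound 1 `C#Cc1cccc(Nc2ncnc3sc(NC(=O)/C=C/c4ccccc4)cc23)c1` gives 4640 nM in a functional assay on HeLa cells (Homo sapiens) for antiproliferative activity, read by MTT assay, with a stated time of 48 h (on this read-out higher numbers stand for weaker inhibition and lower numbers for stronger inhibition), the lowest number among the three measured compounds. Compound 2 `N#Cc1cccc(Nc2ncnc3cc(NC(=O)/C=C/c4ccccc4)sc23)c1` gives 7220 nM, which lies within the scatter of compound 1, so no order between the two is claimed. Compound 3 `COc1ccc(/C=C/C(=O)Nc2cc3ncnc(Nc4ccc(F)c(Cl)c4)c3s2)cc1` gives 20600 nM, a gap beyond the scatter from compound 1. Compound 4 `O=C(/C=C/c1ccccc1)Nc1cc2c(Nc3ccc(F)c(Cl)c3)ncnc2s1` has not been measured; it differs from compound 1 by 3-chloro-4-fluorophenyl in place of 3-ethynylphenyl on a nitrogen on an aromatic ring. Compound 4 shares that aryl amine with compound 3, whose value 20600 nM is the highest recorded, but compound 3 also differs from compound 4 elsewhere, so that comparison is not a clean step. The step expected, a 2.0-fold higher number from compound 1 to compound 4 (0.31 log units; beyond the scatter), is a moderate move toward weaker inhibition, near the edge of the scatter. Compound 4 is thus estimated at 9500 nM, in the range 4000 nM to 24000 nM.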

Compound 4, half-maximal inhibitory concentration: 2140 nM
Compound 4: the middle estimate sits 4.4-fold (0.65 log units) above what was measured; the measured number lies below the stated range.
By their numbers in this assay, from the lowest: compound 4; then compounds 1 and 2 (each within the scatter of the next); then compound 3.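

Going by these compounds alone, on the nitrogen of the aryl amine, 3-chloro-4-fluorophenyl in place of 3-ethynylphenyl gives a 2.2-fold lower number from compound 1 to compound 4 (0.34 log units; beyond the scatter) in this assay, the first step that changes one place only. The triple bond of the ethynyl arm is therefore not required at this position for activity in these cells, and the two halogens serve at least as well. No measured evidence bears on why the number falls. Open, from the compounds shown here alone, is whether one halogen alone would do, as in 3-chlorophenyl or 4-fluorophenyl. Also open, going by these compounds, is how a larger arm such as 3-benzyloxyphenyl would fare at this nitrogen.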